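The source may report more compounds than this note shows. Statements on the series, on what has been measured and on what is new or still open speak of the compounds shown alone.

Working notes on the series: the shared core carries a varied aryl group on a double-bonded chain carbon bound to a double-bonded ring carbon. In a functional assay on SMMC-7721 cells (Homo sapiens) for cytotoxicity, read by MTT assay, with a stated time of 72 h (on this read-out higher numbers stand for weaker inhibition and lower numbers for stronger inhibition), compound 1 `O=C1C(=Cc2ccc(Br)cc2)C(=O)N(c2ccc(Cl)cc2)N1c1ccc(Cl)cc1`, with 4-bromophenyl, gives 16600 nM. Compound 2 `COc1cc(C=C2C(=O)N(c3ccc(Cl)cc3)N(c3ccc(Cl)cc3)C2=O)ccc1O`, with 4-hydroxy-3-methoxyphenyl, gives 64900 nM. Compound 3 `O=C1C(=Cc2ccc(Cl)cc2Cl)C(=O)N(c2ccc(Cl)cc2)N1c1ccc(Cl)cc1`, with 2,4-dichlorophenyl, reads > 128000 nM, which is a limit of the assay and not a number. Its standing is therefore known only as the limit of > 128000 nM in this assay, at which 1 of the 3 values shown sits.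

The next structure is compound 4 `O=C1C(=Cc2ccc(F)cc2F)C(=O)N(c2ccc(Cl)cc2)N1c1ccc(Cl)cc1`, with 2,4-difluorophenyl in place of 2,4-dichlorophenyl at the same place: 2,4-difluorophenyl in place of 2,4-dichlorophenyl on a double-bonded chain carbon bound to a double-bonded ring carbon. Three measured steps change this place: a 3.9-fold higher number from compound 1 to compound 2 (0.59 log units; beyond the scatter), an at least 7.7-fold higher number from compound 1 to compound 3 (0.88 log units; beyond the scatter) and an at least 1.9-fold higher number from compound 2 to compound 3 (0.29 log units; that floor lies within the scatter). None exchanges chlorine for fluorine, so the size of this step has no direct measure. Compound 1 shows that a halogen-bearing phenyl here can give a real number, and an at least 7.7-fold higher number from compound 1 to compound 3 (0.88 log units; beyond the scatter) shows how much the read-out can move with this group alone. A modest move to a lower number is expected in this assay, estimated as an at least 2.5-fold lower number from compound 3 to compound 4 (0.40 log units; beyond the scatter). The estimate for compound 4 is 50000 nM, with an expected range of 14000 nM to 150000 nM.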

Compound 4, half-maximal inhibitory concentration: 35800 nM
Beside the measured number, compound 4's estimate is 1.4-fold (0.15 log units) above it; low and high end bracket the measured number.
By their numbers in this assay, from the lowest: compound 1; then compounds 4 and 2 (each within the scatter of the next). At a limit, above all of these: compound 3.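

In this assay the exchange of 2,4-dichlorophenyl for 2,4-difluorophenyl at this place turns a limit into a real number (an at least 3.5-fold lower number from compound 3 to compound 4 (0.55 log units; beyond the scatter)), so a phenyl carrying two halogens is not tied to the limit of the assay. Compound 3 remains a limit of the assay and not a number, so the size of that step is only a floor: the limit of > 128000 nM in this assay, at which 1 of the 4 values shown sits. Against the other groups, 2,4-difluorophenyl is not separated from 4-hydroxy-3-methoxyphenyl (a 1.8-fold lower number from compound 2 to compound 4 (0.26 log units; within the scatter)), while 4-bromophenyl keeps the lowest number of the series (a 2.2-fold higher number from compound 1 to compound 4 (0.33 log units; beyond the scatter)).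

The compounds shown cannot separate the kind of halogen from the number of halogens on this phenyl, since the step from 4-bromophenyl to 2,4-difluorophenyl changes both at once. As far as these compounds go, how a 4-fluorophenyl, or a phenyl bearing an amine or a carboxylic acid, would read at this place stays open.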